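Adding a sulfonyl group to an iodinated quinolinone core

The source may hold more compounds than are shown below. What is called first, only, known or untested is meant among the compounds shown, and "the series" means these compounds.

The study concerns four closely related compounds tested in a functional assay on SEM cells (Homo sapiens) for antiproliferative activity, with a stated time of 72 h; a lower number here means that less compound is needed, a higher number that more compound is needed for the effect. Compound 1 `COc1ccc(-c2c(Cl)c(=O)c3c(OC)cc(OC)cc3n2S(=O)(=O)c2ccc(OC)cc2)cc1` has no reported result in this assay, the entry being "not determined" (no result reported). Compound 3 `COc1ccc(-c2[nH]c3cc(OC)cc(OC)c3c(=O)c2I)cc1` likewise has no reported result in this assay, the entry being "not determined" (no result reported). For the measured compounds named here, compound 2 `COc1ccc(-c2c(Br)c(=O)c3c(OC)cc(OC)cc3n2S(=O)(=O)c2ccc(OC)cc2)cc1` is the only one with a number: in this assay compound 2 gives 1900 nM. Compound 3 therefore stands nowhere on the measured scale, and no comparison between it and any other compound can be drawn from the numbers.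

Compound 4 `COc1ccc(-c2c(I)c(=O)c3c(OC)cc(OC)cc3n2S(=O)(=O)c2ccc(OC)cc2)cc1` has not yet been measured. It differs from compound 3 in one place: (4-methoxyphenyl)sulfonyl in place of hydrogen on an aromatic nitrogen. Because compound 3 has no value, the size and direction of the step to compound 4 in this assay cannot be predicted from these two compounds alone; what remains is the result of compound 2, which shares the core of compound 4 and also carries the (4-methoxyphenyl)sulfonyl group on the same nitrogen. Relative to compound 2, no difference beyond the usual scatter is expected for compound 4.

Compound 4 is expected to give about 1600 nM in this assay, within a range from 500 nM to 5000 nM.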

Compound 4, half-maximal effective concentration: 5520 nM
The estimate for compound 4 lay 3.5-fold (0.54 log units) below the measured number; the whole stated range lies below it.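

In this assay iodo in place of bromo on an aromatic carbon gives a 2.9-fold higher number from compound 2 to compound 4 (0.46 log units; beyond the scatter) and so shows that the choice of halogen at this position changes the result, even with the (4-methoxyphenyl)sulfonyl group held the same on the aromatic nitrogen. The step is modest, but it means that more compound is needed for the effect with iodo than with bromo, something a single measured number could not show. The steps involving compound 1 or compound 3 cannot be read, so the effect of adding the sulfonyl group remains unknown, and nothing at hand explains the difference between bromo and iodo.

On these data alone, two measured halogens are too few to show a trend, so it remains open how a fluoro group, a methyl group or a nitrile on the same carbon would compare with bromo and iodo. As far as these compounds go, it is also open how far the result depends on the group on the nitrogen, for example whether a methyl group or a benzyl group there would give a number close to that of compound 4.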